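The compounds below may be only part of what the source reports. "The series", "measured", "known", "first", "only" and "open" are said of these compounds alone.

Measured in a functional assay on HepG2 cells (Homo sapiens) for cytotoxicity, read by MTT assay, with a stated time of 24 h; on this read-out lower numbers stand for stronger inhibition and higher numbers for weaker inhibition:
- compound 1 `COc1cc(/C=C2\CN(S(=O)(=O)c3ccc(NC(C)=O)cc3)C/C(=C\c3cc(OC)c(OC)c(OC)c3)C2=O)cc(OC)c1OC`: 3890 nM
- compound 2 `CC(=O)Nc1ccc(S(=O)(=O)N2C/C(=C\c3ccc(C#N)cc3)C(=O)/C(=C/c3ccccc3F)C2)cc1`: 4960 nM
- compound 3 `COc1cc(/C=C2\CN(S(=O)(=O)c3ccc(NC(C)=O)cc3)C/C(=C\c3ccccc3F)C2=O)cc(OC)c1OC`: 4750 nM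

Compound 3, at 4750 nM, lies within the scatter of both other compounds, so it stands in the same range as they do. The unmeasured compound 4 `COc1cc(/C=C2\CN(S(=O)(=O)c3ccc(NC(C)=O)cc3)C/C(=C\c3cc(OC)c(OC)c(OC)c3)C2=O)cc(OC)c1` arises from compound 3 by one change: 3,5-dimethoxyphenyl in place of 2-fluorophenyl on a double-bonded chain carbon bound to a double-bonded ring carbon. Two measured swaps at this kind of place bear on it: a 1.2-fold higher number from compound 1 to compound 3 (0.09 log units; within the scatter), and a 1.0-fold lower number from compound 2 to compound 3 (0.02 log units; within the scatter). Neither left the scatter, so no shift beyond the scatter is expected in this assay. The estimated step is small: a 1.1-fold lower number from compound 3 to compound 4 (0.04 log units; within the scatter). For compound 4 the expected value is 4300 nM, with an estimated range of 2400 nM to 7500 nM.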

Compound 4, half-maximal inhibitory concentration: 4140 nM
Estimate against measurement, compound 4: 1.0-fold (0.02 log units) above; measured number inside the range.
By their numbers in this assay, from the lowest: compounds 1, 4, 3 and 2 (each within the scatter of the next).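

In this assay the exchange at this place gives a 1.1-fold lower number from compound 3 to compound 4 (0.06 log units; within the scatter) and stays within the scatter, even though 3,5-dimethoxyphenyl brings two hydrogen-bond acceptors where 2-fluorophenyl has none. Hydrogen in place of a single methoxy on an aromatic carbon gives a 1.1-fold higher number from compound 1 to compound 4 (0.03 log units; within the scatter), also within the scatter, so this single edit of the ring shows no clear effect either. Nothing available explains this lack of separation. From the compounds shown here alone, whether a phenyl ring carrying an amine or a carboxylic acid at this place would leave this range remains open.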